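Swapping an Aromatic Ring for a Non-Aromatic One

A few compounds are considered here, and "the series" means these few. Any claim that something is new, unique, unknown or untested is made for them only; others in the source may bear on it.

Compound 1 `O=C(Nc1ccc(OC(F)(F)F)cc1)NC1CCN(C(=O)c2ccoc2)CC1` was tested in a physicochemical assay for solubility, read by mass spectrometry, in phosphate buffer, with a stated time of 24 h, at pH 7.4 (a higher number here means a more soluble compound, a lower number a less soluble compound), where compound 1 gives 7.6 ug/mL. Two other compounds share its core: in this assay compound 2 `CC[C@H](C)C(=O)N1CCC(NC(=O)Nc2ccc(OC(F)(F)F)c(OC(F)(F)F)c2)CC1` gives 5.5 ug/mL, and compound 3 `CCC(=O)N1CCC(NC(=O)Nc2ccc(C(F)(F)F)c(F)c2)CC1` gives 3.9 ug/mL. Compound 1 is not set apart from compound 2 or from compound 3 beyond the usual scatter of such measurements, so the three readings count as alike. Compound 4 `O=C(Nc1ccc(OC(F)(F)F)cc1)NC1CCN(C(=O)C2=COCC2)CC1` has not yet been measured. It differs from compound 1 in one place: a group of 5 heavy atoms (4 carbon, 1 oxygen; one five-membered non-aromatic ring with 1 hetero atom) in place of a group of 5 heavy atoms (4 carbon, 1 oxygen; one five-membered aromatic ring with 1 hetero atom), on a carbonyl carbon. For the measured compounds named here, no measured pair shows this change, so there is no precedent to lean on. The step from compound 1 to compound 4 is expected to stay within the scatter, a 1.1-fold lower number from compound 1 to compound 4 (0.04 log units; within the scatter). For compound 4 the expected result in this assay is 7 ug/mL, with a likely range from 3 ug/mL to 16 ug/mL.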

Compound 4, solubility: 11 ug/mL
Compound 4: the middle estimate sits 1.6-fold (0.20 log units) below what was measured; low and high end bracket the measured number.
By their numbers in this assay, from the lowest: compounds 3, 2, 1 and 4 (each within the scatter of the next, the first and the last beyond it).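

In this assay putting the five-membered non-aromatic ring in place of furan-3-yl on the carbonyl carbon gives a 1.4-fold higher number from compound 1 to compound 4 (0.16 log units; within the scatter) and so, at this position, giving up the aromatic ring brings no readable shift. For the compounds shown here, this is the first pair here that differs in one place, which the earlier compounds could not offer. No measurement shown here accounts for the size of this step. Still open, going by these compounds, is whether an amine or a carboxylic acid in place of this ring would reach beyond the scatter.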